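Adding a methoxy group to a purine scaffold

The source may report more compounds than this note shows. Statements on the series, on what has been measured and on what is new or still open speak of the compounds shown alone.

Four compounds of one purine series were compared in a functional assay on K562 cells (Homo sapiens) for antiproliferative activity, read by MTT assay, with a stated time of 48 h; on this read-out higher numbers stand for weaker inhibition of growth and lower numbers for stronger inhibition of growth. Compound 1 `COc1ccc(Cn2cnc3c(N(C)c4ccc(OC)cc4)nc(Cl)nc32)cc1` carries a 4-methoxyphenyl group. In this assay compound 1 reaches only the limit of the assay, > 100000 nM. Compound 2 `COc1ccc(N(C)c2nc(Cl)nc3c2ncn3Cc2ccc(OC)c(OC)c2)cc1` differs by methoxy in place of hydrogen on an aromatic carbon. In this assay compound 2 gives 27000 nM. That change produced an at least 3.7-fold lower number from compound 1 to compound 2 (0.56 log units; beyond the scatter).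

Compound 3 `COc1cc(Cn2cnc3c(Cl)ncnc32)cc(OC)c1` has a different core. In this assay compound 3 also reaches only a limit, > 100000 nM. Two of the three measured values sit at this limit (the limit of > 100000 nM in this assay, at which 2 of the 3 values shown sit). The difference between the core of compound 3 and that of compound 1 is not broken down here.

Compound 4 `COc1cc(Cn2cnc3c(Cl)ncnc32)cc(OC)c1OC` has not been measured. It differs from compound 3 by methoxy in place of hydrogen on an aromatic carbon. This is the same kind of change as that from compound 1 to compound 2, though the surroundings differ: here the entering group is ortho to two methoxy groups and para to a large group, whereas before it was ortho to a methoxy group and meta to a large group. Because the value of compound 3 is only a limit, > 100000 nM, a modest step is expected, an at least 1.4-fold lower number from compound 3 to compound 4 (0.15 log units; that floor lies within the scatter). Compound 4 is estimated at 70000 nM, within 15000 nM and 200000 nM.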

Compound 4, concentration for 50% growth inhibition: > 50000 nM
Compound 4: only a limit was reported; the forecaster's own chance of this, stated with the estimate: 60%; the middle value does not contradict the limit.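

In this assay compound 3 gives only a limit, > 100000 nM. Compound 4 also gives only a limit, > 50000 nM, and the step between these two compounds cannot be read. The compounds shown leave open whether methoxy in place of hydrogen on an aromatic carbon changes growth inhibition at all on the core of compound 3.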